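The source may hold more compounds than are shown below. What is called first, only, known or untested is meant among the compounds shown, and "the series" means these compounds.

Values in a functional assay on BXPC-3 cells (Homo sapiens) for antiproliferative activity, read by MTT assay, with a stated time of 24 h (on this read-out lower numbers stand for stronger inhibition and higher numbers for weaker inhibition), for the measured compounds:
- Compound 1 `CCn1c(C(=O)N[C@H](C)C(=O)OC)ccc1C(CC)(CC)c1ccc(OCS(=O)(=O)c2ccccc2)c(C)c1` gives > 50000 nM as a limit
- Compound 2 `CCn1c(C(=O)NCCC(=O)OC)ccc1C(CC)(CC)c1ccc(OCS(=O)(=O)c2ccccc2)c(C)c1` gives > 50000 nM as a limit
- Compound 3 `CCn1c(C(=O)N[C@@H](CC(=O)OC)C(=O)OC)ccc1C(CC)(CC)c1ccc(OCS(=O)(=O)c2ccccc2)c(C)c1` gives > 50000 nM as a limit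

Among the compounds with values here, none of these is a number, so the series so far has no measured potency and no order. Compound 3 has only its limit to stand on, and the whole set shares it: the limit of > 50000 nM in this assay, at which 3 of the 3 values shown sit, is all that can be said.

Compound 4 `CCn1c(C(=O)NCCN)ccc1C(CC)(CC)c1ccc(OCS(=O)(=O)c2ccccc2)c(C)c1` carries 2-aminoethyl in place of 1,2-bis(methoxycarbonyl)ethyl on an amide-type nitrogen, and the counted difference is 2-aminoethyl in place of 1,2-bis(methoxycarbonyl)ethyl on an amide-type nitrogen in full.

Within the data shown here, the steps that bear on this position are a step that the two limits leave unreadable from compound 1 to compound 2 and a step that the two limits leave unreadable from compound 1 to compound 3 and also a step that the two limits leave unreadable from compound 2 to compound 3 with no size to carry forward. Among the measured compounds shown here, all three stay among chains bearing methoxycarbonyl, and no measured compound carries 2-aminoethyl.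

The expected at least 1.2-fold lower number from compound 3 to compound 4 (0.09 log units; that floor lies within the scatter) in this assay is modest and towards stronger inhibition, though this direction is only weakly supported. The expectation stays close to the limit, as compound 2 with its limit of > 50000 nM is the only other unbranched chain. Compound 4 is estimated at 40000 nM with an expected range from 12000 nM to 80000 nM and a good chance of ending at only a limit.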

Compound 4, half-maximal inhibitory concentration: 6430 nM
Estimate against measurement, compound 4: 6.2-fold (0.79 log units) above; the measured number lies below the stated range.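

In this assay, within the data shown here, compound 4 gives 6430 nM, so the 2-aminoethyl chain on the amide-type nitrogen provides the first measured number and shows that this position can carry activity in the shared core. Each comparison gives only a floor, since the other partner sits at a limit: an at least 7.7-fold lower number from compound 3 to compound 4 (0.89 log units; beyond the scatter), an at least 7.7-fold lower number from compound 1 to compound 4 (0.89 log units; beyond the scatter), and, in the closest comparison, where amino replaces methoxycarbonyl on the chain, an at least 7.7-fold lower number from compound 2 to compound 4 (0.89 log units; beyond the scatter). The steps among the three methoxycarbonyl-bearing compounds cannot be read, so branching and the second ester show no effect on the number, and those chains stay together at one assay limit: the limit of > 50000 nM in this assay, at which 3 of the 4 values shown sit.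

As far as these compounds go, the true size of the drop remains open, as does whether the amino group itself is required, since a single amine-bearing chain stands against the esters. A 2-hydroxyethyl chain, a 3-aminopropyl chain, a 2-(dimethylamino)ethyl chain or a free carboxylic acid would test that requirement, along with chain length and substitution on the nitrogen.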